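This account rests on a few compounds, and the source may have more. Where it says the series, first, only, none or still open, it means among the compounds named here.

Measured compounds:
compound 1, `Cc1nc(N)nc(N[C@@H]2C[C@H](CO)[C@@H](O)[C@H]2O)c1-c1nc2ccccc2s1`: 4000 nM
compound 2, `Cc1nc(NCCNS(C)(=O)=O)nc(N[C@@H]2C[C@H](CO)[C@@H](O)[C@H]2O)c1-c1nc2ccccc2s1`: > 25000 nM

In an ADME assay on cells (Homo sapiens) for cytotoxicity, read by polymerase chain reaction, with a stated time of 3 days (on this read-out lower numbers stand for higher toxicity in this test and higher numbers for lower toxicity in this test), compound 1 gives 4000 nM. Compound 2 stands at a limit of this assay, > 25000 nM, so for compound 2 only a limit and no number is known. Among the measured compounds shown here, the single measured step is an at least 6.2-fold higher number from compound 1 to compound 2 (0.79 log units; beyond the scatter); it carries compound 2 to the limit of > 25000 nM in this assay, at which 1 of the 2 values shown sits, so its true size is open-ended.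

Compound 3, `Cc1nc(NCc2nccs2)nc(N[C@@H]2C[C@H](CO)[C@@H](O)[C@H]2O)c1-c1nc2ccccc2s1`, differs from compound 2 by 1,3-thiazol-2-yl in place of (methanesulfonamido)methyl on a saturated chain carbon bound to a nitrogen on an aromatic ring. For the measured compounds named here, no measured step covers this exchange directly; only the step from compound 1 to compound 2 bears on it, and it shows that hydrogen on the ring nitrogen in compound 1 goes with the lower number, while the 2-(methanesulfonamido)ethyl chain of compound 2 moves the number past the limit. Compound 3 keeps a chain on that nitrogen but ends it in an aromatic ring, so compound 3 is expected to fall between the two measured values, with an estimate of 12000 nM, between 4000 nM and 25000 nM. That estimate means an expected step of an at least 2.0-fold lower number from compound 2 to compound 3 (0.31 log units; beyond the scatter), with a fair chance that this assay again reports only a limit.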

Compound 3, half-maximal cytotoxic concentration: 23000 nM
The estimate for compound 3 lay 1.9-fold (0.28 log units) below the measured number; the range from low to high includes it.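

In this assay, replacing the hydrogen on the nitrogen on an aromatic ring now has a size that is more than a limit: (1,3-thiazol-2-yl)methyl gives a 5.8-fold higher number from compound 1 to compound 3 (0.76 log units; beyond the scatter), and so the higher number does not depend on the methanesulfonamido group of compound 2, since compound 2 and compound 3 both stand on the same side of compound 1 and neither goes against this pattern. The exchange at the end of the chain reads an at least 1.0-fold lower number from compound 2 to compound 3 (0.03 log units; that floor lies within the scatter), and this floor does not separate the 1,3-thiazol-2-yl group from the (methanesulfonamido)methyl group. As far as these compounds go, compound 2 remains a limit rather than a number, so the true gap to compound 3 stays unknown: the limit of > 25000 nM in this assay, at which 1 of the 3 values shown sits.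

The compounds shown leave open whether a simple alkyl chain on that nitrogen, with no sulfonamide or aromatic ring at its end, would give the same shift, and whether a primary amine or a carboxylic acid at the end of the chain would do so. They also leave open whether a longer chain between the nitrogen and the 1,3-thiazol-2-yl group would move the number in this assay.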